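Benzyloxy in Place of Methoxy on a Cationic Purine Scaffold

The compounds below may be only part of what the source reports. "The series", "measured", "known", "first", "only" and "open" are said of these compounds alone.

The measured compounds and their values:

Compound 1, `CO/N=c1\[nH]cnc2c1[n+](C/C=C(\C)CC/C=C(\C)CC/C=C(\C)CCC=C(C)C)cn2CCC#N`: 5360 nM
Compound 2, `CC(C)=CCC/C(C)=C/CC/C(C)=C/CC/C(C)=C/C[n+]1cn(CCC#N)c2nc[nH]/c(=N\OCc3ccccc3)c21`: 19100 nM
Compound 3, `CO/N=c1\[nH]cnc2c1[n+](C/C=C(\C)CC/C=C(\C)CC/C=C(\C)CCC=C(C)C)cn2C(c1ccccc1)c1ccccc1`: 3540 nM

All three compounds were tested in a functional assay on CEM/s cells (Homo sapiens) for cytotoxicity; a lower number here means a stronger inhibitor, a higher number a weaker inhibitor. Compound 1 gives 5360 nM in this assay, and compound 2 gives 19100 nM. The structural difference between these two is phenyl in place of hydrogen on a saturated chain carbon bound to an oxygen, and the step it produced is a 3.6-fold higher number from compound 1 to compound 2 (0.55 log units; beyond the scatter). Compound 3 gives 3540 nM; it has the lowest number of the three, but its gap to compound 1 is within the scatter, so no order between compound 3 and compound 1 can be read from these two values. The difference between the core of compound 1 and the core of compound 3 is not broken down here.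

Compound 4, `CC(C)=CCC/C(C)=C/CC/C(C)=C/CC/C(C)=C/C[n+]1cn(C(c2ccccc2)c2ccccc2)c2nc[nH]/c(=N\OCc3ccccc3)c21`, has not yet been measured. It differs from compound 3 by phenyl in place of hydrogen on a saturated chain carbon bound to an oxygen, which is the same change that separates compound 1 from compound 2, made at the same place. Within the data shown here, since the single precedent for this change is the step from compound 1 to compound 2, the expected step for compound 4 is a 3.6-fold higher number from compound 3 to compound 4 (0.55 log units; beyond the scatter) in this assay, resting on the step of a 3.6-fold higher number from compound 1 to compound 2 (0.55 log units; beyond the scatter) applied to the value of compound 3. Compound 4 is therefore estimated to give 12700 nM in this assay, expected to lie between 5000 nM and 32000 nM.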

Compound 4, half-maximal inhibitory concentration: 9110 nM
Compound 4: middle estimate off by 1.4-fold (0.14 log units), on the high side, within the range that was stated.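

In this assay, exchanging methoxy for benzyloxy on the second core again raised the number, giving a 2.6-fold higher number from compound 3 to compound 4 (0.41 log units; beyond the scatter). Set beside the earlier step, the result has the same direction, and the two sizes cannot be told apart: the same change on two cores in this assay, a 3.6-fold higher number (0.55 log units; beyond the scatter) from compound 1 to compound 2 and a 2.6-fold higher number (0.41 log units; beyond the scatter) from compound 3 to compound 4, 1.4-fold (0.14 log units) apart, within the scatter of two such steps

Within this series, the change therefore carried over from the core of compound 1 to the core of compound 3 with a comparable penalty, but these two pairs, read in a single cell assay, show only that much and do not establish a general rule for other cores or explain why the number rises.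

The compounds shown carry only methoxy and benzyloxy at this place, so it remains open how an ethoxy group or a longer straight chain on the oxygen would read, and whether the number would climb steadily from methoxy towards benzyloxy. Also open, going by these compounds, is whether an amine or a carboxylic acid on the phenyl ring of the benzyloxy group would keep, reduce or reverse the step seen on these two cores.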